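The source may report more compounds than this note shows. Statements on the series, on what has been measured and on what is new or still open speak of the compounds shown alone.

Measured so far in a functional assay on MCF7 cells (Homo sapiens) for cytotoxicity, read by sulforhodamine B assay, with a stated time of 48 h; on this read-out lower numbers stand for stronger inhibition and higher numbers for weaker inhibition:
- compound 1 `N#Cc1cc(-c2ccccc2)n(-c2nc3ccccc3[nH]2)c1N` gives 1280 nM
- compound 2 `Nc1c(-c2nc3ccccc3[nH]2)cc(-c2ccccc2)n1-c1ccncc1` gives 705 nM
- compound 3 `Nc1c(-c2nc3ccccc3[nH]2)cc(-c2ccccc2)n1-c1cccc(Cl)c1` gives 1700 nM

Compound 2 stands at the low end of these three numbers, within the scatter of compound 1 and beyond the scatter of compound 3.

Next in the series is compound 4 `Nc1c(-c2nc3ccccc3[nH]2)cc(-c2ccccc2)n1Cc1nc2ccccc2[nH]1`, which departs from compound 2 on an aromatic nitrogen of the shared core. There, (1H-benzimidazol-2-yl)methyl stands in place of pyridin-4-yl: (1H-benzimidazol-2-yl)methyl in place of pyridin-4-yl on an aromatic nitrogen. The site lies next to the ring atom that bears a phenyl group and next to the ring atom that bears an amino group.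

Among the compounds with values here, only one measured step bears on this site: a 2.4-fold higher number from compound 2 to compound 3 (0.38 log units; beyond the scatter), for 3-chlorophenyl in place of pyridin-4-yl. That step is modest and also removes pyridin-4-yl. Within the data shown here, no measured compound carries (1H-benzimidazol-2-yl)methyl on this nitrogen, so the guidance is loose. A modest step toward a higher number is expected in this assay, although a result inside the scatter would fit as well. The expected change is a 1.6-fold higher number from compound 2 to compound 4 (0.19 log units; within the scatter). For compound 4 the estimated value is 1100 nM, with an expected range from 350 nM to 3500 nM.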

Compound 4, half-maximal inhibitory concentration: 972 nM
Compound 4: the middle estimate sits 1.1-fold (0.05 log units) above what was measured; low and high end bracket the measured number.
By their numbers in this assay, from the lowest: compounds 2, 4, 1 and 3 (each within the scatter of the next, the first and the last beyond it).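

In this assay, the nitrogen of the shared core now carries a group of 10 heavy atoms joined through a methyl carbon, and the read-out does not separate it from either group with an aromatic ring joined directly: a 1.4-fold higher number from compound 2 to compound 4 (0.14 log units; within the scatter) against pyridin-4-yl, and a 1.7-fold lower number from compound 3 to compound 4 (0.24 log units; within the scatter) against 3-chlorophenyl. Within the data shown here, compounds 2 and 3 lie beyond the scatter of each other, yet compound 4 lies within the scatter of both, so at this site the series so far shows no loss from the larger substituent, the added methyl link or the added hydrogen-bond donor. Nothing available accounts for these numbers in terms of mechanism.

The change brings in the methyl link and the benzimidazole rings together, so the compounds shown cannot assign any part of the result to either one. Also open, as far as these compounds go, is how this nitrogen would respond to a simple benzyl group, or to an open chain ending in an amine or a carboxylic acid.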